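Alkyne chain in place of ethyl on the aryl ether

The source may hold more compounds than are shown below. What is called first, only, known or untested is meant among the compounds shown, and "the series" means these compounds.

Among the measured compounds shown here, compound 3 `CCCOc1cccc2ccc(N)nc12` is the higher of the two numbers measured so far: in an assay on cells with melanin-concentrating hormone receptor 1 (Homo sapiens) as the target, read by radioligand binding (a lower number here means a stronger inhibitor, a higher number a weaker inhibitor), compound 3 gives 1100 nM. Its nearest neighbour is compound 2 `Nc1ccc2cccc(OCC3CCCC3)c2n1`, which in this assay gives 53 nM, so that a 21-fold higher number from compound 2 to compound 3 (1.32 log units; beyond the scatter). Compound 1 `Nc1ccc2cccc(OCC3CCCO3)c2n1` gives in this assay only a limit, > 2000 nM, (the limit of > 2000 nM in this assay, at which 1 of the 3 values shown sits). Read from that limit, an at least 37-fold lower number from compound 1 to compound 2 (1.57 log units; beyond the scatter), whereas an at least 1.8-fold lower number from compound 1 to compound 3 (0.25 log units; that floor lies within the scatter).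

Compound 4 `CCC#CCOc1cccc2ccc(N)nc12` is the next step from compound 3: but-1-yn-1-yl in place of ethyl on a saturated chain carbon bound to an oxygen on an aromatic ring. The bearing steps are the two around the same chain carbon. Cyclopentyl in place of ethyl gave a large shift, while oxolan-2-yl in place of ethyl gave only a floor within the scatter; but-1-yn-1-yl, with no ring and no oxygen, is closer in kind to cyclopentyl than to oxolan-2-yl. A lower number is therefore expected, but smaller than the cyclopentyl step. For compound 4 the estimate in this assay is 250 nM, with an expected range from 60 nM to 1000 nM. The expected step is a 4.4-fold lower number from compound 3 to compound 4 (0.64 log units; beyond the scatter).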

Compound 4, half-maximal inhibitory concentration: > 2000 nM
Compound 4: a limit, no number; the forecaster's own chance of this, stated with the estimate: 5%; middle value at least 8.0-fold (0.90 log units) away from the limit.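

Compound 4 joins compound 1 at the limit of this assay: the limit of > 2000 nM in this assay, at which 2 of the 4 values shown sit.

Measured against the cyclopentyl group, the but-1-yn-1-yl group gives a large change, an at least 37-fold higher number from compound 2 to compound 4 (1.57 log units; beyond the scatter), so on this saturated chain carbon an open chain with a triple bond does not carry over what the ring gave. Against ethyl the change reads an at least 1.8-fold higher number from compound 3 to compound 4 (0.25 log units; that floor lies within the scatter), so no real loss from compound 3 can be claimed, and the step between the two limits of compound 1 and compound 4 cannot be read.

Still open, from the compounds shown here alone, is whether the triple bond or the chain length goes with the limit result, a question that a saturated butyl chain in the same place would separate. Also open, going by these compounds, is whether other rings, such as cyclobutyl or cyclohexyl, hold the level of compound 2, 53 nM.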